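Moving the hydroxy group from compound 2 to compound 3

The compounds below may be only part of what the source reports. "The series", "measured", "known", "first", "only" and "open" are said of these compounds alone.

- compound 1 `COc1cc(/C=C/C(=O)c2ccccc2F)cc(OC)c1`: 6000 nM
- compound 2 `COc1cc(/C=C/C(=O)c2ccccc2O)cc(OC)c1`: 8100 nM
- compound 3 `COc1cc(/C=C/C(=O)c2cccc(O)c2)cc(OC)c1`: not yet measured

In a functional assay (Homo sapiens) for inhibition (on this read-out lower numbers stand for stronger inhibition and higher numbers for weaker inhibition), compound 2 gives 8100 nM, within the scatter of compound 1 at 6000 nM. The next change is 3-hydroxyphenyl in place of 2-hydroxyphenyl on a carbonyl carbon, with 3-hydroxyphenyl in place of 2-hydroxyphenyl on a carbonyl carbon. Going by the values given here, the one measured step, a 1.4-fold higher number from compound 1 to compound 2 (0.13 log units; within the scatter), put hydroxy in place of fluoro on an aromatic carbon. Among the compounds with values here, no measured step moves a hydroxy group, so the evidence is indirect and gives no direction. No step beyond the scatter is expected. The expected change is a 1.4-fold lower number from compound 2 to compound 3 (0.13 log units; within the scatter). Compound 3 is estimated at 6000 nM, with an expected range of 2000 nM to 18000 nM.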

Compound 3, half-maximal inhibitory concentration: 3200 nM
For compound 3 the middle estimate is 1.9-fold (0.27 log units) above the measured one; the measured number falls inside the stated range.
By their numbers in this assay, from the lowest: compounds 3, 1 and 2 (each within the scatter of the next, the first and the last beyond it).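

In this assay, going by these compounds alone, 3-hydroxyphenyl in place of 2-hydroxyphenyl on the carbonyl carbon gives a 2.5-fold lower number from compound 2 to compound 3 (0.40 log units; beyond the scatter) and is the first step beyond the scatter, so the place of the hydroxy group matters even though both groups have the same atoms. Against the fluoro compound, the change gives a 1.9-fold lower number from compound 1 to compound 3 (0.27 log units; within the scatter) and stays within the scatter. No data at hand explain the difference between the two hydroxyphenyl groups.

Going by these compounds, whether an amine or a carboxylic acid in place of the hydroxy group of compound 3 would hold this level remains open.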